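The source may hold more compounds than are shown below. What is called first, only, known or untested is meant among the compounds shown, and "the series" means these compounds.

Measured in a functional assay on a cell-free system (Platelet, plasma, Homo sapiens) for inhibition, read by turbidimetry, with a stated time of 3 min; on this read-out higher numbers stand for weaker inhibition and lower numbers for stronger inhibition:
- compound 1 `COc1ccc(-n2nc(C(=O)N3CCCCC3)cc2-c2ccc(Cl)cc2)nn1`: 41 nM
- compound 2 `CS(=O)(=O)c1ccc(-n2nc(C(=O)N3CCCCC3)cc2-c2ccc(Cl)cc2)nn1`: 19600 nM
- compound 3 `COc1ccc(-n2nc(C(=O)N3CCCCC3)cc2-c2ccc(Cl)cc2)cc1`: 7.9 nM

Of these three, compound 3 has the lowest number, which means the strongest inhibition. Compound 4 `COc1ccc(-n2nc(C(=O)N3CCCC3)cc2-c2ccc(Cl)cc2)cc1` differs from it in one place: pyrrolidin-1-yl in place of piperidin-1-yl on a carbonyl carbon, with pyrrolidin-1-yl in place of piperidin-1-yl on a carbonyl carbon. Going by the values given here, no measured step touches that place. The available steps, a 5.2-fold lower number from compound 1 to compound 3 (0.72 log units; beyond the scatter) and a 480-fold higher number from compound 1 to compound 2 (2.68 log units; beyond the scatter), involve changes elsewhere, so they show that the numbers can move, but not what this change will do. With no direct evidence, only a small move towards a higher number is expected, perhaps none beyond the scatter. The expected step is a 1.8-fold higher number from compound 3 to compound 4 (0.25 log units; within the scatter). The estimated value for compound 4 is 14 nM, with an expected range of 4 nM to 50 nM.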

Compound 4, half-maximal inhibitory concentration: 5.7 nM
Estimate against measurement, compound 4: 2.5-fold (0.39 log units) above; the measured number falls inside the stated range.
By their numbers in this assay, from the lowest: compounds 4 and 3 (each within the scatter of the next); then compound 1; then compound 2.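

In this assay, putting pyrrolidin-1-yl in place of piperidin-1-yl on the carbonyl carbon gives a 1.4-fold lower number from compound 3 to compound 4 (0.14 log units; within the scatter), so the two compounds cannot be told apart. This is the first change at this position among the compounds shown, and it indicates that, on this core, the five-membered ring serves as well as the six-membered one. No other measurement here bears on this result.

On these data alone, it remains open whether the position also accepts morpholin-4-yl, which carries an oxygen in the ring, or an open-chain diethylamino group. Whether the same swap behaves alike on the core of compound 1 is also unknown.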